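A few compounds are considered here, and "the series" means these few. Any claim that something is new, unique, unknown or untested is made for them only; others in the source may bear on it.

Compound 1 `Cc1nc2cc(OC[C@H](O)CN3CCN(Cc4noc(-c5ccc(Cl)cc5)n4)CC3)ccc2s1` gives 2270 nM in a functional assay on mitochondria from heart for inhibition of peroxisomal acyl-coenzyme A oxidase 1 (Rattus norvegicus); on this read-out higher numbers stand for weaker inhibition and lower numbers for stronger inhibition. Compound 2 `Cc1nc2cc(OC[C@H](O)CN3CCN(Cc4noc(-c5ccc(Cl)cc5Cl)n4)CC3)ccc2s1` gives 130 nM.

Within the data shown here, compound 2 thus stands at the lower of the two numbers, separated from compound 1 by the single measured step, a 17-fold lower number from compound 1 to compound 2 (1.24 log units; beyond the scatter). Compound 3 `Cc1nc2cc(OC[C@H](O)CN3CCN(Cc4noc(-c5cccc(Cl)c5)n4)CC3)ccc2s1` carries 3-chlorophenyl in place of 2,4-dichlorophenyl on an aromatic carbon. Among the measured compounds shown here, that step removes one of the two chlorines and shifts the remaining one to a position not yet examined; only the step from compound 1 to compound 2 bears on it, and it was large. Compound 3 is therefore expected to move back toward compound 1, with an estimated 7.7-fold higher number from compound 2 to compound 3 (0.89 log units; beyond the scatter) giving 1000 nM (range 300 nM to 4000 nM).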

Compound 3, half-maximal inhibitory concentration: 4120 nM
Estimate against measurement, compound 3: 4.1-fold (0.61 log units) below; the measured number lies above the stated range.
By their numbers in this assay, from the lowest: compound 2; then compounds 1 and 3 (each within the scatter of the next).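

In this assay, taking away the 2,4-dichlorophenyl group for 3-chlorophenyl gives up the whole of the earlier gain (a 32-fold higher number from compound 2 to compound 3 (1.50 log units; beyond the scatter)). The two single-chlorine compounds are not told apart (a 1.8-fold higher number from compound 1 to compound 3 (0.26 log units; within the scatter)), so moving the lone chlorine between 4-chlorophenyl and 3-chlorophenyl makes no difference that can be read, and among these compounds only the 2,4-dichlorophenyl group stands apart. Nothing measured here explains this. As far as these compounds go, what remains open is whether methyl or methoxy groups in place of the two chlorines would keep the number of compound 2.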